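Swapping an Ether Side Chain for an Amide on the Core

A few compounds are considered here, and "the series" means these few. Any claim that something is new, unique, unknown or untested is made for them only; others in the source may bear on it.

Measured compounds:
Compound 1 `Cc1noc(C)c1COC1CC(=O)Nc2c1c(C)nn2-c1ncnc2nc[nH]c12` gives 5 nM in a functional assay on HEK293 cells for agonist activity at G-protein coupled receptor 39 (Homo sapiens), read by scintillation proximity assay and inositol phosphate accumulation, with a stated time of 75 min, in the presence of a further agent that is not named here; on this read-out lower numbers stand for an effect already at smaller amounts and higher numbers for an effect only at larger amounts of compound.
Compound 2 `Cc1nn(-c2ncnc3nc[nH]c23)c2c1C(OC(=O)c1ccc(F)cc1)CC(=O)N2` gives 4 nM in this assay.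
Compound 3 `Cc1nn(-c2ncnc3nc[nH]c23)c2c1C(OCc1ccc(Cl)cc1Cl)CC(=O)N2` gives 4 nM in this assay.

All three share the core of compound 1 and differ only in the group attached through an oxygen on a saturated ring carbon. Compound 1 has the highest of the three numbers, but the step of a 1.3-fold lower number from compound 1 to compound 2 (0.10 log units; within the scatter) and the step of a 1.3-fold lower number from compound 1 to compound 3 (0.10 log units; within the scatter) both lie within the scatter, as does no change at the digits printed from compound 2 to compound 3 (within the scatter). The three compounds therefore cannot be told apart on these numbers.

Compound 4 `Cc1nn(-c2ncnc3nc[nH]c23)c2c1C(C(=O)N(C)c1ccccc1)CC(=O)N2` takes a different route: methyl(phenyl)carbamoyl in place of (3,5-dimethyl-1,2-oxazol-4-yl)methoxy on a saturated ring carbon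

The measured steps bear on this change only partly. They show that the group carried by the oxygen can be varied widely without a step beyond the scatter, which suggests this side of the core is forgiving. On these data alone, none of them, however, removes the oxygen itself or places a carbamoyl group directly on the ring carbon, so the new amide link is untested. A modest step is therefore expected for compound 4, if anything toward a somewhat higher number, as a 2.0-fold higher number from compound 1 to compound 4 (0.30 log units; within the scatter), with an estimate of 10 nM in this assay, between 3 nM and 40 nM.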

Compound 4, half-maximal effective concentration: 32 nM
The estimate for compound 4 lay 3.2-fold (0.51 log units) below the measured number, and the stated range covers the measured number.
By their numbers in this assay, from the lowest: compounds 2, 3 and 1 (each within the scatter of the next); then compound 4.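

In this assay, among the compounds shown here, replacing the oxygen-linked group on this saturated ring carbon with methyl(phenyl)carbamoyl gives the first steps beyond the scatter in this set: a 6.4-fold higher number from compound 1 to compound 4 (0.81 log units; beyond the scatter) and an 8.0-fold higher number from compound 3 to compound 4 (0.90 log units; beyond the scatter) and also an 8.0-fold higher number from compound 2 to compound 4 (0.90 log units; beyond the scatter). The freedom seen among the three oxygen-linked groups therefore does not extend to every group at this position, and the same direction appears whichever of them compound 4 is compared with. No measurement shown here accounts for the higher number.

Compound 4 changes both the link to the ring carbon and the group at its end, so these numbers cannot say which of the two matters, or whether a carbamoyl link could do better with another group on its nitrogen. On these data alone, it also remains open how this ring carbon would respond to an amine, a carboxylic acid or a longer chain between the carbonyl and the phenyl ring.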